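Removing the cyclopropyl from the triazole substituent

The source may hold more compounds than are shown below. What is called first, only, known or untested is meant among the compounds shown, and "the series" means these compounds.

The shared core is that of compound 1 `O=C1O[C@H]([C@@H](O)Cn2cc(-c3cc(F)cc(F)c3)nn2)C(OCc2ccccc2)=C1OCc1ccccc1`. In an ADME assay on HFF cells (Homo sapiens) for cytotoxicity, read by MTT assay, with a stated time of 72 h (on this read-out lower numbers stand for stronger inhibition and higher numbers for weaker inhibition), compound 1 gives > 100000 nM, which is a limit of the assay and not a number (the limit of > 100000 nM in this assay, at which 1 of the 3 values shown sits). Compound 2 `O=C1O[C@H]([C@@H](O)Cn2cc(CNS(=O)(=O)c3ccc(F)cc3)nn2)C(OCc2ccccc2)=C1OCc1ccccc1` gives 30 nM in this assay. Compound 3 `O=C1O[C@H]([C@@H](O)Cn2cc(C3CC3)nn2)C(OCc2ccccc2)=C1OCc1ccccc1` gives 24300 nM in this assay, the highest of the two numbers available; its nearest neighbour is compound 2, the step being an 810-fold higher number from compound 2 to compound 3 (2.91 log units; beyond the scatter). Against compound 1 the step reads an at least 4.1-fold lower number from compound 1 to compound 3 (0.61 log units; beyond the scatter).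

Compound 4 `O=C1O[C@H]([C@@H](O)Cn2ccnn2)C(OCc2ccccc2)=C1OCc1ccccc1` differs from compound 3 as follows: hydrogen in place of cyclopropyl on an aromatic carbon. Among the compounds with values here, the steps that bear on this position are an 810-fold higher number from compound 2 to compound 3 (2.91 log units; beyond the scatter), a large one, and an at least 4.1-fold lower number from compound 1 to compound 3 (0.61 log units; beyond the scatter), a more modest one in the opposite direction; no measured step removes the group at this carbon outright, and the two steps do not agree on which way a smaller group moves the number. The change from compound 3 to compound 4 is therefore expected to be small, a 1.6-fold higher number from compound 3 to compound 4 (0.22 log units; within the scatter), leaning toward a higher number. For compound 4 the estimate is 40000 nM, with a range of 10000 nM to 150000 nM.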

Compound 4, half-maximal inhibitory concentration: 610 nM
Compound 4: middle estimate off by 66-fold (1.82 log units), on the high side; measured number below the stated range.
By their numbers in this assay, from the lowest: compound 2; then compound 4; then compound 3. At a limit, above all of these: compound 1.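

In this assay, hydrogen on this aromatic carbon gives a clearly lower number than cyclopropyl (a 40-fold lower number from compound 3 to compound 4 (1.60 log units; beyond the scatter)), so removing the group does not leave the number near that of compound 3. Across hydrogen, cyclopropyl and 3,5-difluorophenyl the number rises in that order, but compound 2 goes against this pattern, since its (((4-fluorophenyl)sulfonyl)amino)methyl group gives the lowest number of the series (a 20-fold higher number from compound 2 to compound 4 (1.31 log units; beyond the scatter)). The comparison with compound 1 gives only a bound (an at least 160-fold lower number from compound 1 to compound 4 (2.21 log units; beyond the scatter)), and the value of compound 1 is a limit of the assay: the limit of > 100000 nM in this assay, at which 1 of the 4 values shown sits.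

The compounds shown leave open which part of the compound 2 substituent goes with its low number. A plain aminomethyl, a methyl or a carboxylic acid on this carbon would help to separate the effect of the chain from that of the sulfonyl and 4-fluorophenyl parts.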